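The source may hold more compounds than are shown below. What is called first, only, known or untested is meant among the compounds shown, and "the series" means these compounds.

Measured compounds:
compound 1, `OC[C@H]1O[C@@H](n2cnc3c(NCc4ccccc4Cl)ncnc32)[C@H](O)[C@@H]1O`: 1600 nM
compound 2, `OC[C@H]1O[C@@H](n2cnc3c(NCc4ccc(Cl)c(Cl)c4)ncnc32)[C@H](O)[C@@H]1O`: 2000 nM
compound 3, `OC[C@H]1O[C@@H](n2cnc3c(NCc4ccc(F)cc4F)ncnc32)[C@H](O)[C@@H]1O`: 3400 nM

In a functional assay on HL-60 cells (Homo sapiens) for antiproliferative activity, with a stated time of 72 h (on this read-out lower numbers stand for stronger inhibition and higher numbers for weaker inhibition), compound 1 gives the lowest of the three numbers, though compound 2 lies within the scatter of it. Compound 4, `OC[C@H]1O[C@@H](n2cnc3c(NCc4ccc(F)c(Cl)c4)ncnc32)[C@H](O)[C@@H]1O`, differs from compound 1 by 3-chloro-4-fluorophenyl in place of 2-chlorophenyl on a saturated chain carbon bound to a nitrogen on an aromatic ring. Among the compounds with values here, two measured steps bear on this: a 1.3-fold higher number from compound 1 to compound 2 (0.10 log units; within the scatter), and a 2.1-fold higher number from compound 1 to compound 3 (0.33 log units; beyond the scatter). Between those two products, a 1.7-fold higher number from compound 2 to compound 3 (0.23 log units; within the scatter). The new group of compound 4 shares its substitution pattern more closely with compound 2 than with compound 3, so a small rise in number, if any, is expected, as a 1.2-fold higher number from compound 1 to compound 4 (0.07 log units; within the scatter). Compound 4 is therefore estimated at 1900 nM, in the range 1000 nM to 3600 nM.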

Compound 4, half-maximal inhibitory concentration: 3500 nM
Compound 4: middle estimate off by 1.8-fold (0.27 log units), on the low side; measured number inside the range.
By their numbers in this assay, from the lowest: compounds 1, 2, 3 and 4 (each within the scatter of the next, the first and the last beyond it).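

In this assay, replacing 2-chlorophenyl with 3-chloro-4-fluorophenyl gives a 2.2-fold higher number from compound 1 to compound 4 (0.34 log units; beyond the scatter), so compound 4 joins compound 3 as a second change at this place that lies beyond the scatter of compound 1. Fluoro in place of chloro on an aromatic carbon, the smallest change shown here, gives a 1.8-fold higher number from compound 2 to compound 4 (0.24 log units; within the scatter), while the step of a 1.0-fold higher number from compound 3 to compound 4 (0.01 log units; within the scatter) leaves the two fluorinated rings unseparated. Nothing at hand accounts for these steps. On these data alone, what an unsubstituted phenyl or a methoxyphenyl would give at this place remains open, as does the effect of a longer chain between the ring and the nitrogen.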